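The source may hold more compounds than are shown below. What is called first, only, known or untested is meant among the compounds shown, and "the series" means these compounds.

The study measured a small set of chalcone-type compounds in an assay on A549 cells for inhibition of transcription factor p65 (Homo sapiens), read by fluorescence, with a stated time of 2 h; on this read-out higher numbers stand for weaker inhibition and lower numbers for stronger inhibition. Compound 1, with the structure `COc1ccc(/C=C/C(=O)c2cccc(-c3ccc(F)cc3)c2)cc1`, gave a reading of > 50000 nM, which is a limit of the assay rather than a number. Two further compounds carry an amino group on the shared core and a dimethoxyphenyl group on it: compound 2, `COc1ccc(-c2cc(C(=O)/C=C/c3cc(OC)c(OC)c(OC)c3)ccc2N)cc1OC`, gives 5440 nM in this assay, and compound 3, `COc1ccc(-c2cc(C(=O)/C=C/c3cccc(OC)c3OC)ccc2N)cc1OC`, gives 11900 nM. For the measured compounds named here, compound 1 therefore stands only at the limit of > 50000 nM in this assay, at which 1 of the 3 values shown sits, and no step between measured compounds that differ in a single place is available to set a scale.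

Compound 4, with the structure `COc1ccc(/C=C/C(=O)c2cccc(-c3cccc(F)c3)c2)cc1`, differs from compound 1 in one place: 3-fluorophenyl in place of 4-fluorophenyl on an aromatic carbon. The fluorine moves on the pendant ring while everything else in the molecule is kept. With compound 1 itself resting at a limit, the data give no basis for expecting a change in either direction beyond the usual scatter, so the step from compound 1 to compound 4 is expected to be a step that the limit leaves unreadable from compound 1 to compound 4. Compound 4 is accordingly expected to come out near 80000 nM, in the range of 30000 nM to 200000 nM, and most probably as another limit rather than a number.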

Compound 4, half-maximal inhibitory concentration: > 50000 nM
Compound 4 gave a limit, no number; the forecaster's own chance of this, stated with the estimate: 80%; the middle value lies beyond the limit too.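

Compound 4, like compound 1, rests at a limit of the assay and not at a number, so no step can be read between compound 1 and compound 4: the limit of > 50000 nM in this assay, at which 2 of the 4 values shown sit. The compounds shown in this assay leave open whether 3-fluorophenyl in place of 4-fluorophenyl changes the inhibition of transcription factor p65 at all.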